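Amino to dimethylamino: an estimate for compound 4

The source may hold more compounds than are shown below. What is called first, only, known or untested is meant among the compounds shown, and "the series" means these compounds.

In a functional assay on SK-BR-3 cells (Homo sapiens) for antiproliferative activity, with a stated time of 48 h (on this read-out higher numbers stand for an effect only at larger amounts of compound and lower numbers for an effect already at smaller amounts), compound 1 `Nc1ccc(NC(=O)CCCCCCC(=O)NO)cc1` gives 8500 nM, the middle of the three measured numbers. Compound 2 `O=C(CCCCCCC(=O)Nc1cccc(C(F)(F)F)c1)NO` gives 26000 nM, the highest, and compound 3 `O=C(CCCCCCC(=O)Nc1ccc(Cl)cc1)NO` gives 2300 nM, the lowest.

Compound 4 `CN(C)c1ccc(NC(=O)CCCCCCC(=O)NO)cc1` is not yet measured. Its difference from compound 1 is dimethylamino in place of amino on an aromatic carbon, para to a large group.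

Going by the values given here, only one measured step changes this amino group, and it is modest and beyond the scatter: a 3.7-fold lower number from compound 1 to compound 3 (0.57 log units; beyond the scatter). Among the compounds with values here, compound 2 differs from compound 1 in more than one place, so it gives no single-change step. Within the data shown here, no measured compound carries dimethylamino, so the chloro step is only a loose guide to size and direction. On that basis, a small move toward lower numbers is expected, probably smaller than the chloro step and not clearly beyond the scatter. The estimated change is a 1.4-fold lower number from compound 1 to compound 4 (0.15 log units; within the scatter). For compound 4 the expected value is 6000 nM, with an estimated range from 2000 nM to 17000 nM.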

Compound 4, half-maximal effective concentration: 4200 nM
Compound 4: middle estimate off by 1.4-fold (0.15 log units), on the high side, within the range that was stated.
By their numbers in this assay, from the lowest: compounds 3 and 4 (each within the scatter of the next); then compound 1; then compound 2.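

In this assay, going by these compounds alone, chloro was until now the only group seen to replace amino on this aromatic carbon, para to a large group, and dimethylamino moves the number the same way (a 2.0-fold lower number from compound 1 to compound 4 (0.31 log units; beyond the scatter)), so the nitrogen is kept while the hydrogen-bond donors of the amino group are lost. The second new step (a 1.8-fold higher number from compound 3 to compound 4 (0.26 log units; within the scatter)) does not separate dimethylamino from chloro, so these two very different groups cannot be told apart at this position. Nothing shown here gives a measured reason for either step.

The compounds shown leave open how a methylamino or a methoxy group would read at this position, which would show whether the trend extends to other nitrogen or oxygen groups. They also leave open whether a longer chain on the core of compound 4 would keep this number.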